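The source may hold more compounds than are shown below. What is called first, only, known or untested is meant among the compounds shown, and "the series" means these compounds.

Working notes on the series. In a functional assay on A549 cells (Homo sapiens) for cytotoxicity, read by MTT assay, with a stated time of 72 h (on this read-out higher numbers stand for weaker inhibition and lower numbers for stronger inhibition), compound 1 `CCOC(=O)c1sc2ccccc2c1Nc1cc(OC)c(OC)c(OC)c1` gives 8530 nM, and compound 3 `CCOC(=O)c1sc2cccc(C)c2c1Nc1cc(OC)c(OC)c(OC)c1` gives 6250 nM; the two differ by hydrogen in place of methyl on an aromatic carbon, and this step is a 1.4-fold higher number from compound 3 to compound 1 (0.14 log units; within the scatter). Compound 2 `COC(=O)c1sc2nc(C)ccc2c1Nc1cc(OC)c(OC)c(OC)c1` gives 16.2 nM in this assay, the lowest of the three numbers; the difference between its core and that of compound 3 is not broken down here. Compound 4 `COC(=O)c1sc2ncccc2c1Nc1cc(OC)c(OC)c(OC)c1` is not yet measured. It differs from compound 2 by hydrogen in place of methyl on an aromatic carbon. This is the same kind of change as that from compound 3 to compound 1, but the place is not the same: here the ring holds 1 nitrogen, the carbon is next to the ring nitrogen and meta and para to a fused ring, whereas there the ring was of carbon only and the carbon ortho and meta to a fused ring. Because a 1.4-fold higher number from compound 3 to compound 1 (0.14 log units; within the scatter) is small, a step of about a 1.5-fold higher number from compound 2 to compound 4 (0.19 log units; within the scatter) is expected from compound 2 to compound 4. For compound 4 the estimate in this assay is 25 nM, with a range from 8 nM to 100 nM.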

Compound 4, half-maximal inhibitory concentration: 3850 nM
Beside the measured number, compound 4's estimate is 150-fold (2.19 log units) below it; the measured number lies above the stated range.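

In this assay, hydrogen in place of methyl on an aromatic carbon gives a 240-fold higher number from compound 2 to compound 4 (2.38 log units; beyond the scatter), so on the core of compound 2 the methyl goes with the much lower number. The size of this step does not carry from one core to the other in this series: the same change on two cores in this assay, a 1.4-fold higher number (0.14 log units; within the scatter) from compound 3 to compound 1 and a 240-fold higher number (2.38 log units; beyond the scatter) from compound 2 to compound 4, 170-fold (2.24 log units) apart, beyond the scatter of two such steps The two pairs differ from each other both in the ring that carries the methyl and in the ester, and the data do not separate these differences or give a cause for the gap.

Going by these compounds, it remains open whether the low number of compound 2 is particular to methyl or also holds with an ethyl group, a chlorine atom or an amine on that carbon.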